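From propoxycarbonyl to ethylcarbamoyl at the assay limit

The source may report more compounds than this note shows. Statements on the series, on what has been measured and on what is new or still open speak of the compounds shown alone.

In a functional assay on cells (Platelet, Homo sapiens) for inhibition (a higher number here means a weaker inhibitor, a lower number a stronger inhibitor), compound 1 (`CCOC(=O)c1ccc(-c2nn(Cc3ccccc3OC)c3ccccc23)cc1`) gives > 10000 nM as a limit of the assay and not a number. Compound 2 (`CCCOC(=O)c1ccc(-c2nn(Cc3ccccc3)c3ccccc23)cc1`) gives > 10000 nM in this assay as well, again a limit and not a number. Among the compounds with values here, the evidence so far is the limit of > 10000 nM in this assay, at which 2 of the 2 values shown sit, and the series offers no measured step from which to read a size of change.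

Compound 3 (`CCNC(=O)c1ccc(-c2nn(Cc3ccccc3)c3ccccc23)cc1`) is the next to be read. The change from compound 2 is ethylamino in place of propoxy on a carbonyl carbon with ethylamino in place of propoxy on a carbonyl carbon.

With compound 2 standing at > 10000 nM as a limit, no step beyond the scatter is expected in this assay and no direction is favoured. The estimated change is a step that the limit leaves unreadable from compound 2 to compound 3 as a working figure only. For compound 3 the expected value is 14000 nM with an estimated range from 4000 nM to 50000 nM and a report as a limit is the likely outcome.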

Compound 3, half-maximal inhibitory concentration: > 10000 nM
Compound 3 was reported as a limit; the forecaster's own chance of this, stated with the estimate: 75%; the middle value does not contradict the limit.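

Within the data shown here, compound 3 gives [ > 10000 nM ] in this assay, a limit and not a number; compound 2 also stands at a limit, so no step between them can be read. The compounds shown leave open how far any of them lies from that limit.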